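Swapping a Dimethylamino for a Chloropyridinylmethylamino Group

This account rests on a few compounds, and the source may have more. Where it says the series, first, only, none or still open, it means among the compounds named here.

Measured compounds:
- compound 1, `CC(C)CNc1ccc(NC(=O)c2cc(Cl)ccc2O)c(Cl)c1`: 60000 nM
- compound 2, `O=C(Nc1ccc(NCC2CCCC2)cc1Cl)c1cc(Cl)ccc1O`: 21500 nM
- compound 3, `CN(C)c1ccc(NC(=O)c2cc(Cl)ccc2O)c(Cl)c1`: 85100 nM

All three share one core and differ only in the amino group on an aromatic carbon. In an ADME assay on A549 cells (Homo sapiens) for cytotoxicity, read by resazurin assay, with a stated time of 48 h (on this read-out higher numbers stand for lower toxicity in this test and lower numbers for higher toxicity in this test), compound 3 gives the highest of the three numbers. Its gap to compound 1 is within the scatter, but the step of a 4.0-fold higher number from compound 2 to compound 3 (0.60 log units; beyond the scatter) is beyond it, so compound 3 does stand apart from compound 2.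

Compound 4, `O=C(Nc1ccc(NCc2cccnc2Cl)cc1Cl)c1cc(Cl)ccc1O`, changes compound 3 at that same place: ((2-chloropyridin-3-yl)methyl)amino in place of dimethylamino on an aromatic carbon. The entering group, like the (cyclopentylmethyl)amino of compound 2, carries a ring on a saturated chain carbon bound to the ring nitrogen. Within the data shown here, the steps that bear on this are a 1.4-fold higher number from compound 1 to compound 3 (0.15 log units; within the scatter), a small one, and a 4.0-fold higher number from compound 2 to compound 3 (0.60 log units; beyond the scatter), a modest one. Reversing the latter direction, compound 4 is expected to give a lower number than compound 3 in this assay, by about a 3.4-fold lower number from compound 3 to compound 4 (0.53 log units; beyond the scatter). The estimate for compound 4 is 25000 nM, with a range from 8000 nM to 70000 nM.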

Compound 4, half-maximal cytotoxic concentration: 101000 nM
Beside the measured number, compound 4's estimate is 4.0-fold (0.61 log units) below it, and the stated range ends below it.
By their numbers in this assay, from the lowest: compound 2; then compounds 1, 3 and 4 (each within the scatter of the next).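

In this assay, a ring on the saturated chain carbon does not by itself bring a lower number at this position: the far larger ((2-chloropyridin-3-yl)methyl)amino group leaves the number within the scatter of dimethylamino (a 1.2-fold higher number from compound 3 to compound 4 (0.07 log units; within the scatter)). The ring's identity matters here, since 2-chloropyridin-3-yl in place of cyclopentyl gives a step beyond the scatter (a 4.7-fold higher number from compound 2 to compound 4 (0.67 log units; beyond the scatter)), whereas in place of isopropyl it stays within the scatter (a 1.7-fold higher number from compound 1 to compound 4 (0.23 log units; within the scatter)). Compound 2 is therefore the only one of these four that stands apart, and its cyclopentyl group, rather than ring-bearing groups in general, marks the difference.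

A plain benzylamino group, with neither the ring nitrogen nor the ring chlorine, could show which of those two atoms separates compound 4 from compound 2. No evidence at hand explains the difference between these two rings.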